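Amine substituent change from compound 3 to compound 4

This account rests on a few compounds, and the source may have more. Where it says the series, first, only, none or still open, it means among the compounds named here.

Values in a functional assay on CWR22R cells (Homo sapiens) for antiproliferative activity, read by CCK-8 assay, with a stated time of 6 days; on this read-out higher numbers stand for weaker inhibition and lower numbers for stronger inhibition:
Compound 1 `C[C@@H](Cn1ccc(-c2ccc(C#N)c(Cl)c2)n1)NC(=O)c1ccccc1`: "not determined" (no result reported)
Compound 2 `C[C@@H](Cn1ccc(-c2ccc(C#N)c(Cl)c2)n1)Nc1ccccn1`: > 30000 nM (a limit, not a number)
Compound 3 `C[C@@H](Cn1ccc(-c2ccc(C#N)c(Cl)c2)n1)Nc1ccncc1`: 11500 nM
Compound 4 `C[C@@H](Cn1ccc(-c2ccc(C#N)c(Cl)c2)n1)Nc1ncnc2nc[nH]c12`: not yet measured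

Within the data shown here, compound 3, at 11500 nM, holds the only actual number in this small set. Compound 2 stands at > 30000 nM, which is a limit of the assay. Compound 1 has no result and offers no comparison.

The change now in view is a group of 9 heavy atoms (5 carbon, 4 nitrogen; one five-membered aromatic ring with 2 hetero atoms, one six-membered aromatic ring with 2 hetero atoms) in place of a group of 6 heavy atoms (5 carbon, 1 nitrogen; one six-membered aromatic ring with 1 hetero atom), on an amine nitrogen. Among the measured compounds shown here, one measured step bears on it: an at least 2.6-fold lower number from compound 2 to compound 3 (0.41 log units; beyond the scatter). That step swaps one pyridinyl attachment for another on the same amine nitrogen, whereas the group entering in compound 4 is of a different kind, so it is only a weak guide. It gives no direction for this change, and no shift beyond the scatter in this assay is expected, though with wide uncertainty. Also relevant is the limit of > 30000 nM in this assay, at which 1 of the 3 values shown sits, which compound 4 could be expected to reach as well.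

The expected step is a 1.0-fold lower number from compound 3 to compound 4 (0.02 log units; within the scatter), an estimate that carries no firm direction. For compound 4 the estimated value is 11000 nM, with an expected range of 3500 nM to 30000 nM.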

Compound 4, half-maximal inhibitory concentration: 4240 nM
The estimate for compound 4 lay 2.6-fold (0.41 log units) above the measured number; the measured number falls inside the stated range.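

In this assay the amine nitrogen takes a group with one five-membered and one six-membered aromatic ring in place of pyridin-4-yl, and this change gives a 2.7-fold lower number from compound 3 to compound 4 (0.43 log units; beyond the scatter) and so a step beyond the scatter. Among these compounds, this is the first sign that a group larger than a single pyridinyl ring is accepted on this nitrogen without loss, although compound 4 at 4240 nM remains a weak inhibitor in this assay on these numbers. The comparison with the pyridin-2-yl analogue gives an at least 7.0-fold lower number from compound 2 to compound 4 (0.84 log units; beyond the scatter) and this is a bound and not a size: the limit of > 30000 nM in this assay, at which 1 of the 4 values shown sits.

The compounds shown do not separate what the five-membered ring contributes from what the six-membered ring and its added nitrogens contribute, nor do they separate either from the hydrogen-bond donor that enters with the new group, so a pyrimidin-4-yl group alone or a methyl group on the ring nitrogen that carries the hydrogen remains an open comparison. Also open, on these data alone, is how a quinolin-4-yl group, with two rings but fewer nitrogens, would read on the same amine nitrogen.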